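A few compounds are considered here, and "the series" means these few. Any claim that something is new, unique, unknown or untested is made for them only; others in the source may bear on it.

Compound 3 `C[C@H]1[C@H](NCc2cccs2)C[C@H]2C[C@@H]1C2(C)C`: 25000 nM
Compound 1 `C[C@H]1[C@H](NCc2ccsc2)C[C@H]2C[C@@H]1C2(C)C`: 50000 nM
Compound 2 `C[C@H]1[C@H](NCc2cncnc2)C[C@H]2C[C@@H]1C2(C)C`: > 100000 nM

In an ADME assay on MDCK cells (Canis lupus familiaris) for cytotoxicity, read by microscopy, with a stated time of 48 h (a lower number here means that less compound is tolerated, a higher number that more compound is tolerated), compound 3 stands lowest of the two numbers given; the nearest is compound 1, and the step of a 2.0-fold lower number from compound 1 to compound 3 (0.30 log units; within the scatter) stays within the scatter. For compound 2 the result is only a limit, (the limit of > 100000 nM in this assay, at which 1 of the 3 values shown sits). For the measured compounds named here, the one step beyond the scatter is an at least 4.0-fold lower number from compound 2 to compound 3 (0.60 log units; beyond the scatter), and an at least 2.0-fold higher number from compound 1 to compound 2 (0.30 log units; that floor lies within the scatter) reaches only the limit.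

Compound 4 `C[C@H]1[C@H](NCc2sccc2-c2ccsc2)C[C@H]2C[C@@H]1C2(C)C` differs from compound 3 by thiophen-3-yl in place of hydrogen on an aromatic carbon. Going by the values given here, every measured step exchanges one aromatic group for another on the saturated chain carbon bound to an amine nitrogen; none adds a second ring onto the thiophen-2-yl, so no step among them bears directly on this change. Compound 4 is therefore expected to stay close to compound 3, with no change at the digits printed from compound 3 to compound 4 (within the scatter) no larger than the scatter. For compound 4 the estimate is 25000 nM, between 10000 nM and 60000 nM.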

Compound 4, minimum cytotoxic concentration: 12500 nM
Estimate against measurement, compound 4: 2.0-fold (0.30 log units) above, within the range that was stated.
By their numbers in this assay, from the lowest: compounds 4, 3 and 1 (each within the scatter of the next, the first and the last beyond it). At a limit, above all of these: compound 2.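

Compound 4 is the first compound shown with a substituent on the thiophene ring itself, rather than an exchange of one aromatic group for another. In this assay, placing thiophen-3-yl on this aromatic carbon, two ring bonds from the ring sulfur, gives a 2.0-fold lower number from compound 3 to compound 4 (0.30 log units; within the scatter), so this position carries a second ring without a step beyond the scatter. No measurement shown here gives a reason for this step.

Only this one group has been shown at this position. Going by these compounds, whether a carboxylic acid or an amine there would give a step beyond the scatter remains open.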